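From thiophen-2-yl to furan-2-yl on the shared core

This account rests on a few compounds, and the source may have more. Where it says the series, first, only, none or still open, it means among the compounds named here.

In a functional assay on HeLa S3 cells (Homo sapiens) for cytotoxicity, read by XTT assay, with a stated time of 6 days (on this read-out lower numbers stand for stronger inhibition and higher numbers for weaker inhibition), compound 1 `Nc1ncnc2[nH]cc(Sc3cccs3)c12` gives 17900 nM. For compound 2 `c1csc(Sc2c[nH]c3ncnc(-c4cccs4)c23)c1` the reading of > 25000 nM is a limit and not a number. Compound 3 `c1coc(-c2ncnc3[nH]cc(Sc4cccs4)c23)c1` carries furan-2-yl in place of thiophen-2-yl on an aromatic carbon. Within the data shown here, the one measured step is an at least 1.3-fold higher number from compound 1 to compound 2 (0.14 log units; that floor lies within the scatter), a different change that replaces amino, so it gives no size for this swap. The nearest guide is the limit of > 25000 nM in this assay, at which 1 of the 2 values shown sits, and no step beyond the scatter is expected in this assay. The expected step is a step that the limit leaves unreadable from compound 2 to compound 3. For compound 3 the estimate is 28000 nM, with an expected range from 12000 nM to 60000 nM.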

Compound 3, half-maximal inhibitory concentration: 8490 nM
For compound 3 the middle estimate is 3.3-fold (0.52 log units) above the measured one; measured number below the stated range.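

The swap at this position, on an aromatic carbon next to the ring nitrogen, keeps the ring size and changes only the ring's hetero atom, yet in this assay it gives an at least 2.9-fold lower number from compound 2 to compound 3 (0.46 log units; beyond the scatter). Compound 2 reads as a limit, so that step is only a floor: the limit of > 25000 nM in this assay, at which 1 of the 3 values shown sits. Furan-2-yl also compares well with amino, with a 2.1-fold lower number from compound 1 to compound 3 (0.32 log units; beyond the scatter), so the two five-membered rings do not behave alike here.

On these data alone, what causes this difference stays open. So does how a phenyl ring or a longer-chain amine would fare at this position.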